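The compounds below may be only part of what the source reports. "The series", "measured", "known", "first", "only" and "open" are said of these compounds alone.

Measured so far: compound 1 `COC(=O)CC1c2ccccc2N=C(c2ccccc2)N1c1ccccc1`, compound 2 `O=C(CC1c2ccccc2N=C(N2CCOCC2)N1c1ccccc1)NCc1ccccc1`, compound 3 `Nc1ccc(CNC(=O)CC2c3ccccc3N=C(N3CCCCC3)N2c2ccccc2)cc1`.

In a functional assay on HEK293 cells for inhibition of Voltage-dependent T-type calcium channel subunit alpha-1G (Homo sapiens) (a higher number here means a weaker inhibitor, a lower number a stronger inhibitor), compound 1 gives 10700 nM. In this assay compound 2 gives 21600 nM. In this assay compound 3 gives 14400 nM. Compound 3 stands second highest of the three numbers; its nearest neighbour is compound 1 and its furthest is compound 2, and both gaps lie within the scatter, so the three measured compounds cannot be ordered against one another on these data.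

Compound 4 `O=C(CC1c2ccccc2N=C(N2CCCCC2)N1c1ccccc1)NCc1ccc(NS(=O)(=O)c2ccc(F)cc2)cc1` is not yet measured. It differs from compound 3 in one place: (4-fluorophenyl)sulfonyl in place of hydrogen on a nitrogen on an aromatic ring. For the measured compounds named here, no pair of measured compounds differs in a single place, so no step of known size exists to lean on, and nothing shows how the benzylamide end of the shared core tolerates a large addition. The measured numbers are all weak and close together. A change of this size is expected to move the number somewhat; a step toward a lower number, modest and barely beyond the scatter, is the working expectation, but the uncertainty is wide. Compound 4 is expected to come in at 5000 nM, with a range of 1500 nM to 20000 nM, which means an estimated step of a 2.9-fold lower number from compound 3 to compound 4 (0.46 log units; beyond the scatter).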

Compound 4, half-maximal inhibitory concentration: 200 nM
For compound 4 the middle estimate is 25-fold (1.40 log units) above the measured one; measured number below the stated range.
By their numbers in this assay, from the lowest: compound 4; then compounds 1, 3 and 2 (each within the scatter of the next, the first and the last beyond it).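

In this assay, for the compounds shown here, the change from amino to ((4-fluorophenyl)sulfonyl)amino gives a 72-fold lower number from compound 3 to compound 4 (1.86 log units; beyond the scatter), the first step of known size. This shows that a nitrogen on an aromatic ring is a place where a large addition is not only tolerated on the shared core but can move the number strongly toward a stronger inhibitor, which the closely grouped earlier compounds gave no sign of. No measurement here bears on the reason for the size of this step.

It remains open whether the step depends on the sulfonyl link, the phenyl ring or the fluorine, since the compounds shown carry no methylsulfonyl, acetyl or unsubstituted phenylsulfonyl group on that nitrogen. From the compounds shown here alone, whether the same addition has a similar effect alongside other groups on the shared core also remains open.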